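Dropping a Methyl from Two Quinolinone Imines

The compounds below may be only part of what the source reports. "The series", "measured", "known", "first", "only" and "open" are said of these compounds alone.

Measured compounds:
compound 1, `CCCC/N=C/c1cc2cc(C)ccc2[nH]c1=O`: 63200 nM
compound 2, `Cc1ccc2[nH]c(=O)c(/C=N/c3ccc(S(N)(=O)=O)cc3)cc2c1`: "not active" (no number reported)
compound 3, `CCCC/N=C/c1cc2ccccc2[nH]c1=O`: 439000 nM

In a functional assay, read by spectrophotometry, with a stated time of 30 min (on this read-out higher numbers stand for weaker inhibition and lower numbers for stronger inhibition), compound 1 gives 63200 nM, and compound 3 gives 439000 nM. The two differ by hydrogen in place of methyl on an aromatic carbon, and this step is a 6.9-fold higher number from compound 1 to compound 3 (0.84 log units; beyond the scatter). In this assay compound 2 gives "not active" (no number reported), with no number behind it. How the core of compound 2 differs from that of compound 1 is not broken down here.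

Compound 4, `NS(=O)(=O)c1ccc(/N=C/c2cc3ccccc3[nH]c2=O)cc1`, has not been measured. It is related to compound 2 by hydrogen in place of methyl on an aromatic carbon, the same change that separates compound 1 from compound 3, since the two place descriptions agree word for word. Because a 6.9-fold higher number from compound 1 to compound 3 (0.84 log units; beyond the scatter) weakened inhibition and compound 2 already stands without a number, compound 4 is expected to be at least as weak as compound 2 and to be reported, most likely, as a limit rather than a number. The estimate for compound 4 in this assay is 800000 nM, within 200000 nM to 3000000 nM.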

Compound 4, half-maximal inhibitory concentration: 266000 nM
For compound 4 the middle estimate is 3.0-fold (0.48 log units) above the measured one; the range from low to high includes it.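

In this assay compound 2 gives "not active" (no number reported) and compound 4 gives 266000 nM, so no step can be read between them. The compounds shown leave open whether hydrogen in place of methyl moves the number the same way in this pair as between compound 1 and compound 3. No evidence shown here bears on this result.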